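Aryl Swap at the Alkyne: Pyridyl to Methoxyphenyl

The source may hold more compounds than are shown below. What is called first, only, known or untested is meant among the compounds shown, and "the series" means these compounds.

Compound 1 `COC(=O)c1sc2cc(C#Cc3ccc(N)cc3)cnc2c1N`: 8900 nM
Compound 2 `COC(=O)c1sc2cc(C#Cc3cccnc3)cnc2c1N`: a limit only, > 150000 nM

In a functional assay on NCI-H460 cells (Homo sapiens) for inhibition, read by sulforhodamine B assay, with a stated time of 48 h (on this read-out higher numbers stand for weaker inhibition of growth and lower numbers for stronger inhibition of growth), compound 1 gives 8900 nM. For compound 2 the assay reports no number, only > 150000 nM. Compound 2 therefore stands at the limit of > 150000 nM in this assay, at which 1 of the 2 values shown sits. Compound 3 `COC(=O)c1sc2cc(C#Cc3cccc(OC)c3)cnc2c1N` differs from compound 2 by 3-methoxyphenyl in place of pyridin-3-yl on a triple-bonded carbon. Among the compounds with values here, the single measured step, an at least 16-fold higher number from compound 1 to compound 2 (1.22 log units; beyond the scatter), shows that replacing a ring of carbon only with pyridin-3-yl weakened growth inhibition greatly; compound 3 returns to a ring of carbon only, now bearing 3-methoxyphenyl. A step toward stronger inhibition is expected, an at least 6.0-fold lower number from compound 2 to compound 3 (0.77 log units; beyond the scatter), with uncertain size. Compound 3 is estimated at 25000 nM, between 6000 nM and 150000 nM.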

Compound 3, concentration for 50% growth inhibition: 49000 nM
For compound 3 the middle estimate is 2.0-fold (0.29 log units) below the measured one; low and high end bracket the measured number.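

In this assay, a ring of carbon only at this triple-bonded carbon recovers part of the growth inhibition, with 3-methoxyphenyl in place of pyridin-3-yl giving an at least 3.0-fold lower number from compound 2 to compound 3 (0.48 log units; beyond the scatter). On these data alone, the value for compound 2 is only a limit, so the true size of this step remains unknown: the limit of > 150000 nM in this assay, at which 1 of the 3 values shown sits. The recovery is incomplete, as 3-methoxyphenyl in place of 4-aminophenyl gives a 5.5-fold higher number from compound 1 to compound 3 (0.74 log units; beyond the scatter).

As far as these compounds go, whether the amine or its place on the ring matters more stays open, and 3-aminophenyl or 4-methoxyphenyl would separate the two. From the compounds shown here alone, how an unsubstituted phenyl would compare also remains open.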